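Removing a methoxy group on the fused ring of compound 3

The compounds below may be only part of what the source reports. "The series", "measured", "known", "first", "only" and "open" are said of these compounds alone.

Three analogues sharing one core have been measured in a functional assay on ACHN cells (Homo sapiens) for cytotoxicity, read by MTT assay, with a stated time of 48 h; on this read-out lower numbers stand for stronger inhibition and higher numbers for weaker inhibition. Compound 1 `COc1ccc(-c2cc(C(=O)Nc3nc4ccc(Cl)cc4s3)nc3cc(-c4ccccc4)nn23)cc1OC` gives 7760 nM. Compound 2 `COc1cc(-c2cc(C(=O)Nc3nc4ccc(Cl)cc4s3)nc3cc(-c4ccccc4)nn23)cc(OC)c1OC` gives 41700 nM, and compound 3 `COc1ccc(-c2cc(C(=O)Nc3nc4ccc(OC)cc4s3)nc3cc(-c4ccccc4)nn23)cc1` gives 38300 nM. Between compound 2 and compound 1 the change is hydrogen in place of methoxy on an aromatic carbon, and this gave a 5.4-fold lower number from compound 2 to compound 1 (0.73 log units; beyond the scatter). The difference between the cores of compound 2 and compound 3 is not broken down here; their numbers are within the scatter of each other.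

Compound 4 `COc1ccc(-c2cc(C(=O)Nc3nc4ccccc4s3)nc3cc(-c4ccccc4)nn23)cc1` has not yet been measured. It differs from compound 3 by hydrogen in place of methoxy on an aromatic carbon. Among the compounds with values here, this is the same kind of change as the one from compound 2 to compound 1, but the place is not the same: there the methoxy left a six-membered carbon ring ortho to a methoxy group, meta to a large group and meta to a methoxy group, whereas here it leaves a six-membered carbon ring that is part of a fused or bridged system of two rings, meta and para to a fused ring. Because the earlier step was a 5.4-fold lower number from compound 2 to compound 1 (0.73 log units; beyond the scatter), a lowering of the number is expected for compound 4 too, though with less confidence given the different surroundings; the expected step from compound 3 is a 2.6-fold lower number from compound 3 to compound 4 (0.41 log units; beyond the scatter). Compound 4 is thus estimated to give 15000 nM in this assay, with a likely range from 5000 nM to 45000 nM.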

Compound 4, half-maximal inhibitory concentration: 1690 nM
For compound 4 the middle estimate is 8.9-fold (0.95 log units) above the measured one; the measured number lies below the stated range.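

In this assay, the loss of the methoxy group from the ring that is part of the fused system, which turns 6-methoxy-1,3-benzothiazol-2-yl into 1,3-benzothiazol-2-yl, gave a 23-fold lower number from compound 3 to compound 4 (1.36 log units; beyond the scatter). The same kind of change therefore lowered the number on both cores, but the size of the step did not carry over from one core to the other: the same change on two cores in this assay, a 5.4-fold lower number (0.73 log units; beyond the scatter) from compound 2 to compound 1 and a 23-fold lower number (1.36 log units; beyond the scatter) from compound 3 to compound 4, 4.2-fold (0.63 log units) apart, beyond the scatter of two such steps. This shows only that, in these two pairs, the direction was shared and the size was not a fixed property of exchanging methoxy for hydrogen; with one pair per core, and with the methoxy leaving a different ring in each pair, it cannot show whether the gap between the steps belongs to the place of the change or to the rest of the molecule.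

The compounds shown leave open how a chloro group on the fused ring compares with hydrogen or methoxy when everything else in the molecule stays the same. They also leave open what an amine or a carboxylic acid in that same place would do to the number in this assay, and whether the lowering would hold on a third core.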